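Replacing thiophen-2-yl with 1H-pyrrol-2-yl in compound 2

The source may report more compounds than this note shows. Statements on the series, on what has been measured and on what is new or still open speak of the compounds shown alone.

Compound 1 `C=C(Br)C(=O)Nc1ccc2c(c1)/C(=C\c1ccc(C)s1)C(=O)N2`: 2000 nM
Compound 2 `C=C(Br)C(=O)Nc1ccc2c(c1)/C(=C/c1cccs1)C(=O)N2`: 1700 nM
Compound 3 `C=C(Br)C(=O)Nc1ccc2c(c1)/C(=C\c1cccs1)C(=O)N2`: 1800 nM

These three values come from a functional assay on HeLa cells (Homo sapiens) for antiproliferative activity, read by MTT assay, with a stated time of 72 h; on this read-out higher numbers stand for weaker inhibition and lower numbers for stronger inhibition. Compound 2, at 1700 nM, stands level with the other two compounds, as its gaps to both lie within the scatter. The unmeasured compound 4 `C=C(Br)C(=O)Nc1ccc2c(c1)/C(=C/c1ccc[nH]1)C(=O)N2` differs from it in a single group: 1H-pyrrol-2-yl in place of thiophen-2-yl on a double-bonded chain carbon bound to a double-bonded ring carbon. In words, 1H-pyrrol-2-yl sits in place of thiophen-2-yl on a double-bonded chain carbon bound to a double-bonded ring carbon.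

Within the data shown here, two measured steps bear on this part of the molecule. Putting hydrogen in place of methyl on an aromatic carbon gives a 1.1-fold lower number from compound 1 to compound 3 (0.05 log units; within the scatter). Changing the double bond from Z to E gives a 1.1-fold higher number from compound 2 to compound 3 (0.02 log units; within the scatter). Both steps are small, and neither moves the value beyond the scatter. Neither step exchanges the ring itself, however, so the swap in compound 4 has no direct precedent among these compounds, and the range must stay wide. In this assay no shift beyond the scatter is expected, and the expected step is a 1.1-fold lower number from compound 2 to compound 4 (0.05 log units; within the scatter). For compound 4 the estimated value is 1500 nM, with an expected range from 500 nM to 4500 nM.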

Compound 4, half-maximal inhibitory concentration: 500 nM
Compound 4: middle estimate off by 3.0-fold (0.48 log units), on the high side; the measured number falls inside the stated range.
By their numbers in this assay, from the lowest: compound 4; then compounds 2, 3 and 1 (each within the scatter of the next).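

In this assay, the ring on this double-bonded chain carbon turns out to matter: 1H-pyrrol-2-yl in place of thiophen-2-yl gives a 3.4-fold lower number from compound 2 to compound 4 (0.53 log units; beyond the scatter), while the earlier changes, a 1.1-fold lower number from compound 1 to compound 3 (0.05 log units; within the scatter) and a 1.1-fold higher number from compound 2 to compound 3 (0.02 log units; within the scatter), both stayed within the scatter. The two rings have the same size and the same count of heavy atoms, so the step goes with an exchange of sulfur for nitrogen, which brings in a hydrogen-bond donor and removes a hydrogen-bond acceptor, although these compounds cannot show which of these features is responsible. The double bond is drawn the same way in compound 2 and compound 4, so this step does not come from configuration, and a change of configuration alone did not move the number beyond the scatter among the thiophen-2-yl compounds: the fact that compounds 2 and 3 differ only in the configuration as drawn.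

From the compounds shown here alone, whether the hydrogen on the ring nitrogen is what counts stays open, and a 1-methyl-1H-pyrrol-2-yl or furan-2-yl group in this place would speak to that. Also open, going by these compounds, is whether the 1H-pyrrol-2-yl compound would keep its number with the double bond drawn the other way.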